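Swapping a Chloro for a Methoxy on a Shared Core

A few compounds are considered here, and "the series" means these few. Any claim that something is new, unique, unknown or untested is made for them only; others in the source may bear on it.

Compound 1 `O=C1CSC(c2cccc(Cl)c2)N1CCN1CCCCC1` carries a chloro group on its aromatic ring. For the measured compounds named here, in an ADME assay on Vero cells (Chlorocebus sabaeus) for cytotoxicity, read by neutral red uptake, tested at 787 ug/mL (on this read-out higher numbers stand for a weaker effect at the one concentration tested and lower numbers for a stronger effect), compound 1 gives 31%, the highest of the two numbers measured so far, so at the single concentration tested it is the milder of the two. Its neighbour, compound 2 `Cc1ccc(C2SCC(=O)N2CCN2CCCCC2)cc1`, differs only in the group on that ring and in this assay compound 2 gives 17%. The step of a number 14 percentage points lower from compound 1 to compound 2 (beyond the scatter) shows that changing the substituent on this aromatic ring can shift the read-out by a modest amount.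

Compound 3 `COc1cccc(C2SCC(=O)N2CCN2CCCCC2)c1` is the next member: methoxy in place of chloro on an aromatic carbon. Going by the values given here, the one measured step involves a different exchange of ring substituents, so it bears only loosely on this change; it does show that such exchanges here have moved the number by a modest size rather than a large one. The expected step is therefore modest and of uncertain direction, a number 6 percentage points lower from compound 1 to compound 3 (within the scatter). Compound 3 is estimated to give 25% in this assay, with a likely range from 10% to 42%.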

Compound 3, a percentage reported as activity, at one concentration (the size of the read-out at that concentration, not a potency): 19%
Compound 3: middle estimate off by 6 percentage points, on the high side; the measured number falls inside the stated range.
By their numbers in this assay, from the lowest: compounds 2 and 3 (each within the scatter of the next); then compound 1.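

In this assay, the exchange of methoxy for chloro gives a number 12 percentage points lower from compound 1 to compound 3 (beyond the scatter), and this time the group changes while its place on the ring, meta to a large group, stays the same; the earlier step swapped 3-chlorophenyl for 4-methylphenyl, altering the group and its place together. This cleaner comparison shows that changing the group at this one place is enough to move the read-out beyond the scatter, towards a stronger effect at the single concentration tested, and it leaves compound 3 at 19% within the scatter of compound 2 at 17%. Nothing available accounts for why the number moves with this exchange.

For the compounds shown here, with only three compounds, it remains open whether the higher number of compound 1 is particular to chloro or whether other groups at the same place, such as an amine, a hydroxyl or a carboxylic acid, would give a similar number. A methyl at this same place would also separate the effect of the group from the effect of its place on the ring, which compound 2 cannot do.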